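Phenyl in Place of Thiophene on a Shared Core

The source may hold more compounds than are shown below. What is called first, only, known or untested is meant among the compounds shown, and "the series" means these compounds.

Compound 3 `Cc1nc(N)c2c(-c3ccsc3)cn([C@@H]3O[C@H](CO)[C@@H](O)[C@H]3O)c2n1` is the starting point. In a functional assay on K562 cells (Homo sapiens), read by MTT assay, with a stated time of 72 h (on this read-out higher numbers stand for weaker inhibition and lower numbers for stronger inhibition), compound 3 gives only a limit of the assay, > 20000 nM. Compound 1 `Nc1nc(N)c2c(-c3ccsc3)cn([C@@H]3O[C@H](CO)[C@@H](O)[C@H]3O)c2n1` shares the core and the thiophen-3-yl group. In this assay compound 1 likewise gives only a limit, > 20000 nM. The step that the two limits leave unreadable from compound 1 to compound 3 therefore cannot be read, as the limit of > 20000 nM in this assay, at which 2 of the 3 values shown sit, records. Going by the values given here, compound 2 `C#Cc1cn([C@@H]2O[C@H](CO)[C@@H](O)[C@H]2O)c2ncnc(OC)c12` rests on a different core; in this assay compound 2 gives 380 nM, but no single step links it to compound 3. The change to compound 4 `Cc1nc(N)c2c(-c3ccccc3)cn([C@@H]3O[C@H](CO)[C@@H](O)[C@H]3O)c2n1` is phenyl in place of thiophen-3-yl on an aromatic carbon. Among the compounds with values here, no measured step covers this exchange, so the measured numbers give no direction for it. Compound 4 is expected to give 20000 nM, within 5000 nM to 60000 nM. The expected step is a number no higher from compound 3 to compound 4 (the limit leaves the size open).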

Compound 4, half-maximal inhibitory concentration: > 20000 nM
Compound 4: a limit, no number; the forecaster's own chance of this, stated with the estimate: 70%; the middle value sits exactly at the limit.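

In this assay, going by these compounds alone, compound 3 and compound 4 each give only a limit, so no step between them can be read: the limit of > 20000 nM in this assay, at which 3 of the 4 values shown sit.

As far as these compounds go, whether phenyl and thiophen-3-yl differ in strength of inhibition on this shared core stays open.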